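The source may report more compounds than this note shows. Statements on the series, on what has been measured and on what is new or still open speak of the compounds shown alone.

The compounds share one core, seen first in compound 1 `N#CC1=C(N)Oc2c(c3nc4ccccc4nc3c3ccccc23)C12C(=O)N(Cc1cnnn1-c1ccc(S(N)(=O)=O)cc1)c1ccccc12`. In a functional assay on HCT-116 cells (Homo sapiens) for antiproliferative activity, read by MTT assay, with a stated time of 48 h (on this read-out higher numbers stand for weaker inhibition and lower numbers for stronger inhibition), compound 1 gives 31200 nM. Compound 2 `Cc1cc(C)cc(-n2nncc2CN2C(=O)C3(C(C#N)=C(N)Oc4c3c3nc5ccccc5nc3c3ccccc43)c3ccccc32)c1` carries a 3,5-dimethylphenyl on an aromatic nitrogen in place of the 4-sulfamoylphenyl of compound 1. In this assay compound 2 gives > 50000 nM, which is a limit of the assay and not a number. That change reads as an at least 1.6-fold higher number from compound 1 to compound 2 (0.20 log units; that floor lies within the scatter). Compound 3 `Cc1ccccc1-n1nncc1CN1C(=O)C2(C(C#N)=C(N)Oc3c(N)cc4nc5ccccc5nc4c32)c2ccccc21` is the third measured compound. In this assay compound 3 gives > 50000 nM, again a limit of the assay and not a number. Compound 3 thus stands at the limit of > 50000 nM in this assay, at which 2 of the 3 values shown sit. Compound 4 `N#CC1=C(N)Oc2c(N)cc3nc4ccccc4nc3c2C12C(=O)N(Cc1cnnn1-c1ccccc1Br)c1ccccc12` differs from compound 3 by bromo in place of methyl on an aromatic carbon. Going by the values given here, no measured step touches that phenyl; the only measured step, an at least 1.6-fold higher number from compound 1 to compound 2 (0.20 log units; that floor lies within the scatter), concerns a different aryl on an aromatic nitrogen and is itself bounded by a limit. The step of a number no higher from compound 3 to compound 4 (the limit leaves the size open) is therefore expected to be none beyond the scatter, with compound 4 likely remaining at the limit. Compound 4 is estimated at 50000 nM, in the range 20000 nM to 120000 nM.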

Compound 4, half-maximal inhibitory concentration: 12400 nM
Estimate against measurement, compound 4: 4.0-fold (0.61 log units) above, outside the stated range (below it).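

Bromo in place of methyl on this aromatic carbon, ortho to a large group, gives an at least 4.0-fold lower number from compound 3 to compound 4 (0.60 log units; beyond the scatter) in this assay. This is the first step among the compounds shown that lies beyond the scatter, since the only earlier step concerned a different aryl and its floor stayed within the scatter. Compound 3 sits at a limit of the assay and not at a number, so the full size of the step stays open: the limit of > 50000 nM in this assay, at which 2 of the 4 values shown sit.

The compounds shown leave open whether this response is particular to bromo, or whether chloro, methoxy or plain hydrogen on the same carbon would give a similar value. They also leave open whether 2-bromophenyl would have the same effect on the core of compound 1.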